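Swapping the acyl group for a sulfonyl on a thiourea

A few compounds are considered here, and "the series" means these few. Any claim that something is new, unique, unknown or untested is made for them only; others in the source may bear on it.

Measured compounds in an ADME assay on Huh-7 cells (Homo sapiens) for cytotoxicity; on this read-out higher numbers stand for lower toxicity in this test and lower numbers for higher toxicity in this test:
compound 1 `O=C(NC(=S)N1CCc2c(OCCCCCOc3ccc(Cl)cc3)cccc21)c1ccc(F)cc1` gives 31100 nM
compound 2 `O=C(NC(=S)N1CCc2c(OCCCCCOc3ccc(Cl)cc3)cccc21)c1ccc(Cl)cc1` gives 21700 nM
compound 3 `O=C(NC(=S)N1CCc2c(OCCCCCOc3ccc(Cl)cc3)cccc21)c1ccco1` gives 4620 nM

Compound 3 holds the lowest number of the three. The step of a 6.7-fold lower number from compound 1 to compound 3 (0.83 log units; beyond the scatter) and the step of a 4.7-fold lower number from compound 2 to compound 3 (0.67 log units; beyond the scatter) both run downward and both lie beyond the scatter, while the step of a 1.4-fold lower number from compound 1 to compound 2 (0.16 log units; within the scatter) stays within it. The unmeasured compound 4 `O=S(=O)(NC(=S)N1CCc2c(OCCCCCOc3ccc(Cl)cc3)cccc21)c1ccccc1` differs from compound 3 in one place: phenylsulfonyl in place of (furan-2-yl)carbonyl on an amide-type nitrogen. Among the measured compounds shown here, no measured step bears on this change directly. The two steps that do exist show that the group attached to the thiourea moves the number in this assay by a modest amount, and that the two six-membered carbon rings of compound 1 and compound 2 stand higher than the five-membered ring of compound 3. On that basis compound 4 is expected to move back upward by a 2.6-fold higher number from compound 3 to compound 4 (0.41 log units; beyond the scatter), a modest step, with wide uncertainty. The estimate for compound 4 is 12000 nM, with a range from 3500 nM to 40000 nM.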

Compound 4, half-maximal cytotoxic concentration: > 50000 nM
Compound 4 ended at the assay's limit; the forecaster's own chance of this, stated with the estimate: 15%; middle value at least 4.1-fold (0.61 log units) from the limit.
By their numbers in this assay, from the lowest: compound 3; then compounds 2 and 1 (each within the scatter of the next). At a limit, above all of these: compound 4.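

In this assay compound 4 sits at a limit of the assay, so its entry is a limit and not a number: the limit of > 50000 nM in this assay, at which 1 of the 4 values shown sits. Phenylsulfonyl on the amide-type nitrogen gives an at least 10-fold higher number from compound 3 to compound 4 (1.03 log units; beyond the scatter) against (furan-2-yl)carbonyl and an at least 2.3-fold higher number from compound 2 to compound 4 (0.36 log units; beyond the scatter) against (4-chlorophenyl)carbonyl, so a change at this nitrogen away from a carbonyl link can carry the number past these acyl compounds. Against (4-fluorophenyl)carbonyl it gives an at least 1.6-fold higher number from compound 1 to compound 4 (0.20 log units; that floor lies within the scatter), a floor that does not set the two compounds apart.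

The compounds shown leave open how much of the rise belongs to the sulfonyl link and how much to the ring, as the two change together in every step. Going by these compounds, a plain benzoyl group or a furan-2-ylsulfonyl group on this nitrogen would separate them, and the true size of each step stays unknown at the limit.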